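This account rests on a few compounds, and the source may have more. Where it says the series, first, only, none or still open, it means among the compounds named here.

Compound 1 `ClCc1cccc(Cn2cnc3ncnc(Cl)c32)c1`: 13200 nM in a functional assay on BT-549 cells (Homo sapiens) for cytotoxicity, read by sulforhodamine B assay, with a stated time of 48 h; a higher number here means a weaker inhibitor of growth, a lower number a stronger inhibitor of growth
Compound 2 `ClCc1cccc(Cn2cnc3c(Cl)ncnc32)c1`: 15100 nM in this assay
Compound 3 `ClCc1cccc(Cn2cnc3c(Cl)nc(Cl)nc32)c1`: 1690 nM in this assay

Compound 1 and compound 2 carry the same atoms joined differently; the difference between the two cores is not broken down here, and their values sit within the scatter of each other. Compound 3 grows out of compound 2 by chloro in place of hydrogen on an aromatic carbon, and that step gave an 8.9-fold lower number from compound 2 to compound 3 (0.95 log units; beyond the scatter). Compound 4 `ClCc1cccc(Cn2cnc3nc(Cl)nc(Cl)c32)c1`, not yet measured, grows out of compound 1 by chloro in place of hydrogen on an aromatic carbon. The place described for both changes is the same word for word, so this is the same change made on the other core. Because compound 2 to compound 3 showed an 8.9-fold lower number from compound 2 to compound 3 (0.95 log units; beyond the scatter), a step of about that size is expected here, an 8.8-fold lower number from compound 1 to compound 4 (0.94 log units; beyond the scatter). For compound 4 the estimate in this assay is 1500 nM, between 600 nM and 4000 nM.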

Compound 4, concentration for 50% growth inhibition: 480 nM
For compound 4 the middle estimate is 3.1-fold (0.49 log units) above the measured one; the whole stated range lies above it.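

Carried to the other core, chloro in place of hydrogen on an aromatic carbon gave a 28-fold lower number from compound 1 to compound 4 (1.44 log units; beyond the scatter) in this assay. The direction of the change held on both cores, but its size did not carry over unchanged: the same change on two cores in this assay, an 8.9-fold lower number (0.95 log units; beyond the scatter) from compound 2 to compound 3 and a 28-fold lower number (1.44 log units; beyond the scatter) from compound 1 to compound 4, 3.1-fold (0.49 log units) apart, beyond the scatter of two such steps. Two pairs of compounds cannot show why the size differs, or whether the direction would hold on a further core.

The compounds shown leave open whether a group other than chloro at this place, such as an amine or a methoxy group, would also lower the number. They also leave open whether either of those groups would give steps of different size on the two cores.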